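A few compounds are considered here, and "the series" means these few. Any claim that something is new, unique, unknown or untested is made for them only; others in the source may bear on it.

Measured in a functional assay on L5178Y cells (Mus musculus) for inhibition, read by MTT assay, with a stated time of 24 h; a lower number here means a stronger inhibitor, a higher number a weaker inhibitor:
- Compound 1 `COc1cc(O)c2c(c1)O[C@H](c1ccc(O)cc1)C/C2=N\Nc1ccccc1`: >= 11300 nM
- Compound 2 `COc1cc(O)c2c(c1)O[C@H](c1ccc(OCC3CO3)cc1)CC2=O`: >= 11300 nM
- Compound 3 `COc1cc(O)c2c(c1)O[C@H](c1ccc(OCC(O)CNC3CCN(Cc4ccccc4)CC3)cc1)CC2=O`: >= 11300 nM

None of these three entries is a number. Each is a limit of the assay, as the limit of >= 11300 nM in this assay, at which 3 of the 3 values shown sit, records. Compound 2 stands only at the limit >= 11300 nM. For the measured compounds named here, the other two compounds are limits as well, so compound 2 cannot be ranked against them, and no measured step is available to size a structural change.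

Compound 4 `COc1cc(O)c2c(c1)O[C@H](c1ccc(OCC(O)CSc3ccccc3)cc1)CC2=O` carries 1-hydroxy-2-(phenylsulfanyl)ethyl in place of oxiran-2-yl on a saturated chain carbon bound to an oxygen on an aromatic ring.

Compound 2 offers only the limit >= 11300 nM as a starting point, so no step beyond the scatter is expected in this assay, in either direction. The expected step is a step that the limit leaves unreadable from compound 2 to compound 4. A report of compound 4 as a limit again is the most likely outcome. Compound 4 is estimated at 12000 nM, with an expected range from 4000 nM to 30000 nM.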

Compound 4, half-maximal inhibitory concentration: >= 11300 nM
Compound 4 was reported as a limit (the forecaster's own chance of this, stated with the estimate: 70%); the middle value lies beyond the limit too.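

Compound 4, like compound 2, is reported only as a limit and not as a number, so no step can be read between them. The compounds shown leave open whether 1-hydroxy-2-(phenylsulfanyl)ethyl in place of oxiran-2-yl changes inhibition at all in this assay.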